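This account rests on a few compounds, and the source may have more. Where it says the series, first, only, none or still open, it means among the compounds named here.

Series notes. The shared core is that of compound 1 `O=C1NC(=S)/C(=C/c2ccc(Cl)cc2)S1`, which in a functional assay on NCI-H292 cells (Homo sapiens) for cytotoxicity, read by MTT assay, with a stated time of 72 h, tested at 2.5 ug/mL (on this read-out lower numbers stand for less inhibition of growth and higher numbers for more inhibition of growth at the one concentration tested), gives 28.6%. Compound 2 `O=C1NC(=S)/C(=C/c2ccccc2Br)S1` gives 16.2% in this assay, and compound 3 `O=C1NC(=S)/C(=C/c2cccc(F)c2)S1` gives 3.43%. Among the three numbers, compound 2 stands second highest: the nearest is compound 1, higher by a margin beyond the scatter, and the furthest is compound 3, lower by a margin also beyond the scatter. Compound 4 `O=C1NC(=S)/C(=C/c2ccccc2F)S1` has not yet been measured in this assay. It differs from compound 2 in one place: fluoro in place of bromo on an aromatic carbon. No measured pair in the set isolates this change, so the expected size of the step rests only on the three numbers shown. A downward step is expected, of modest size and possibly within the scatter, because compound 3 gives 3.43% while also carrying fluoro. Compound 4 is therefore estimated at 8%, with a range from 0% to 20%. The implied step a number 8.2 percentage points lower from compound 2 to compound 4 (within the scatter) is expected to be downward.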

Compound 4, percent growth inhibition at one concentration: 7.78%
Compound 4: the middle estimate sits 0.2 percentage points above what was measured, within the range that was stated.
By their numbers in this assay, from the lowest: compounds 3, 4 and 2 (each within the scatter of the next, the first and the last beyond it); then compound 1.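

Among the compounds shown here, compound 2 and compound 4 form the first pair that isolates a single change, and in this assay the result is a number 8.4 percentage points lower from compound 2 to compound 4 (within the scatter). At this one place, on an aromatic carbon ortho to a group of 8 heavy atoms, the read-out therefore does not resolve fluoro in place of bromo from the usual scatter of repeated measurements. No measured evidence is available to explain this result.

The compounds shown leave open whether a larger step would appear at the same carbon with a methoxy group, an amine or a carboxylic acid. They also leave open whether fluoro in place of bromo gives a similar step on other carbons of the ring, since this single pair speaks for one place only.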